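Chloro for Fluoro on Two Quinazoline Sulfonamide Scaffolds

The source may hold more compounds than are shown below. What is called first, only, known or untested is meant among the compounds shown, and "the series" means these compounds.

Measured compounds:
- compound 1 `COc1cc2ncnc(Nc3cccc(Cl)c3)c2cc1OCCCCC(=O)Nc1ccc(S(N)(=O)=O)cc1` gives 11200 nM
- compound 2 `COc1cc2ncnc(Nc3cccc(F)c3)c2cc1OCCCCC(=O)Nc1ccc(S(N)(=O)=O)cc1` gives > 40000 nM
- compound 3 `NS(=O)(=O)c1ccc(NC(=S)Nc2ccc3ncnc(Nc4cccc(F)c4)c3c2)cc1` gives 25900 nM

All three were tested in a functional assay on A549 cells (Homo sapiens) for antiproliferative activity, read by MTT assay, with a stated time of 72 h; on this read-out lower numbers stand for stronger inhibition and higher numbers for weaker inhibition. For compound 2 the read-out is a limit of the assay rather than a number, namely (the limit of > 40000 nM in this assay, at which 1 of the 3 values shown sits). Compound 1 and compound 2 share one core and differ only by chloro in place of fluoro on an aromatic carbon; this change gave an at least 3.5-fold lower number from compound 2 to compound 1 (0.55 log units; beyond the scatter). Compound 3 carries a different core, and the difference between the two cores is not broken down here. Within this assay, compound 3 gives a higher number than compound 1, a gap that lies beyond the usual scatter.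

Compound 4 `NS(=O)(=O)c1ccc(NC(=S)Nc2ccc3ncnc(Nc4cccc(Cl)c4)c3c2)cc1` has not yet been measured. It stands to compound 3 as compound 1 stands to compound 2: the difference is chloro in place of fluoro on an aromatic carbon, and since the place of the change reads the same in both pairs, it is the same change. The step from compound 3 to compound 4 is expected to be a 3.2-fold lower number from compound 3 to compound 4 (0.51 log units; beyond the scatter), and this expectation rests on the step of an at least 3.5-fold lower number from compound 2 to compound 1 (0.55 log units; beyond the scatter), taken with some caution. Compound 4 is therefore expected to give about 8000 nM in this assay, most likely between 3000 nM and 25000 nM.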

Compound 4, half-maximal inhibitory concentration: > 40000 nM
Compound 4: only a limit was reported; the forecaster's own chance of this, stated with the estimate: 5%; middle value at least 5.0-fold (0.69 log units) away from the limit.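

In this assay compound 4 gives > 40000 nM, which is a limit of the assay and not a number. Chloro in place of fluoro gave an at least 1.5-fold higher number from compound 3 to compound 4 (0.18 log units; that floor lies within the scatter), so the clear gain seen on the core of compound 1 did not carry over to the core of compound 3, and the two results do not agree: the same change on two cores in this assay, an at least 3.5-fold lower number (0.55 log units; beyond the scatter) from compound 2 to compound 1 and an at least 1.5-fold higher number (0.18 log units; that floor lies within the scatter) from compound 3 to compound 4, at least 5.5-fold (0.74 log units) apart, beyond the scatter of two such steps

This shows that the effect of this change in the series depends on the core it sits on, but with only one pair per core it does not show why, and neither step has a known true size, since each rests on a value that is only a limit: the limit of > 40000 nM in this assay, at which 2 of the 4 values shown sit.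

As far as these compounds go, whether a bromo or a methyl at the same place would follow the pattern of either core remains open, and so does the effect of the same change on any further core. Also open, from the compounds shown here alone, is which of the differences between the two cores decides the outcome, for instance whether a longer chain on the core of compound 3 would bring its behaviour closer to that of compound 1 and compound 2.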